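Working notes: a pyridin-2-yl swap at the limit

The source may hold more compounds than are shown below. What is called first, only, known or untested is meant among the compounds shown, and "the series" means these compounds.

Measured so far in a functional assay on cells (Platelet, Homo sapiens) for inhibition; on this read-out higher numbers stand for weaker inhibition and lower numbers for stronger inhibition (each value is a limit, not a number):
- compound 1 `CCOC(=O)c1ccc(-c2nn(Cc3ccc(Cl)cc3)c3ccccc23)cc1` – > 10000 nM
- compound 2 `CCOC(=O)c1ccc(-c2nn(Cc3ccccc3F)c3ccccc23)cc1` – > 10000 nM
- compound 3 `CCOC(=O)c1ccc(-c2nn(Cc3cccc(F)c3)c3ccccc23)cc1` – > 10000 nM

Compound 3 has no number to its name, only the limit > 10000 nM in this assay. The measured set as a whole stands at the limit of > 10000 nM in this assay, at which 3 of the 3 values shown sit, and no ranking can be read from it.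

Next comes compound 4 `CCOC(=O)c1ccc(-c2nn(Cc3ccccn3)c3ccccc23)cc1`, with this difference: pyridin-2-yl in place of 3-fluorophenyl on a saturated chain carbon bound to an aromatic nitrogen. In words, this is pyridin-2-yl in place of 3-fluorophenyl on a saturated chain carbon bound to an aromatic nitrogen.

For the measured compounds named here, the steps that bear on it are the other swaps at the same place: a step that the two limits leave unreadable from compound 1 to compound 2, a step that the two limits leave unreadable from compound 1 to compound 3 and a step that the two limits leave unreadable from compound 2 to compound 3. None of them has a readable size, and none of them brings a ring with a hetero atom into this place. With the read-out unmoved from the limit across those swaps, no step beyond the scatter is expected in this assay, and no direction can be called.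

The expected step is a step that the limit leaves unreadable from compound 3 to compound 4, and this is only a rough estimate. The estimate for compound 4 is 15000 nM, with an expected range from 5000 nM to 40000 nM, and a report of only a limit is the likeliest outcome.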

Compound 4, half-maximal inhibitory concentration: > 10000 nM
Compound 4: only a limit was reported; the forecaster's own chance of this, stated with the estimate: 80%; the middle value lies beyond the limit too.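

In this assay compound 4 gives > 10000 nM, which is a limit and not a number. Its steps from compound 1, compound 2 and compound 3 therefore cannot be read. The compounds shown leave open whether any group on this saturated chain carbon would bring the read-out off the limit: the limit of > 10000 nM in this assay, at which 4 of the 4 values shown sit.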